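Swapping 3-methylphenyl for 4-chlorophenyl

The source may report more compounds than this note shows. Statements on the series, on what has been measured and on what is new or still open speak of the compounds shown alone.

- compound 1 `Cc1cccc(-c2nnc(CNc3c(C)n(C)n(-c4ccccc4)c3=O)o2)c1` gives 2.39
- compound 2 `Cc1c(NCc2nnc(-c3ccccc3)o2)c(=O)n(-c2ccccc2)n1C` gives 2.02
- compound 3 `COc1ccc(-c2nnc(CNc3c(C)n(C)n(-c4ccccc4)c3=O)o2)cc1` gives 2.07

In a physicochemical assay for lipophilicity, measured as octanol-water partition (on this read-out lower numbers stand for lower lipophilicity and higher numbers for higher lipophilicity), compound 1 stands highest of the three, and both others lie beyond the scatter from it. Compound 4 `Cc1c(NCc2nnc(-c3ccc(Cl)cc3)o2)c(=O)n(-c2ccccc2)n1C` is still unmeasured. It carries 4-chlorophenyl in place of 3-methylphenyl on an aromatic carbon on an aromatic carbon and shares the rest of its structure with compound 1.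

Two measured steps start from the same place. Hydrogen in place of methyl gave a number 0.37 log units lower from compound 1 to compound 2 (beyond the scatter) as a modest step. 4-Methoxyphenyl in place of 3-methylphenyl gave a number 0.32 log units lower from compound 1 to compound 3 (beyond the scatter) as a similarly modest step. Methoxy in place of hydrogen gave a number 0.05 log units higher from compound 2 to compound 3 (within the scatter) within the scatter. None of these compounds contains chlorine, so no direct measure exists. These steps suggest that swaps at this place stay modest, so a small change with no firm direction is expected. The estimated change is a number 0.06 log units higher from compound 1 to compound 4 (within the scatter) and would lie within the scatter. The expected value for compound 4 is 2.45 with an estimated range from 2.1 to 2.8 as its limits.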

Compound 4, partition coefficient: 2.7
Compound 4: middle estimate off by 0.25 log units, on the low side; the measured number falls inside the stated range.
By their numbers in this assay, from the lowest: compounds 2 and 3 (each within the scatter of the next); then compound 1; then compound 4.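

4-Chlorophenyl in place of 3-methylphenyl gives a number 0.31 log units higher from compound 1 to compound 4 (beyond the scatter) in this assay, the only step upward from compound 1 among those shown, so changes at this position can raise the number as well as lower it. Chloro in place of methoxy gives a number 0.63 log units higher from compound 3 to compound 4 (beyond the scatter), and chloro in place of hydrogen gives a number 0.68 log units higher from compound 2 to compound 4 (beyond the scatter), which sets chloro apart from methoxy and hydrogen, two groups that lie within the scatter of each other here. Nothing in the information available accounts for these shifts.

Compound 1 and compound 4 differ in both the substituent and its numbered place on the phenyl ring, so 3-chlorophenyl or 4-methylphenyl would be needed to separate those two changes. On these data alone, how an amine or a carboxylic acid on this phenyl ring would shift the number also remains open.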